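Removing the Ester Methyl from a Weak Bile Acid Receptor Ligand

This account rests on a few compounds, and the source may have more. Where it says the series, first, only, none or still open, it means among the compounds named here.

Compound 1 `COC(=O)/C=C/c1cccc(N(Cc2ccc(/C=C/c3ccccc3F)cc2)C(=O)C2CCCCC2)c1`: 64 nM
Compound 2 `COC(=O)/C=C/c1ccc(CN(C(=O)C2CCCCC2)c2cccc(/C=C/C(=O)OC)c2)cc1`: > 1000 nM

In an assay on isolated protein with Bile acid receptor (Homo sapiens) as the target (a higher number here means that more compound is needed for the effect, a lower number that less compound is needed), compound 1 gives 64 nM. Compound 2 reaches only a limit of the assay, > 1000 nM, the edge of what was measured (the limit of > 1000 nM in this assay, at which 1 of the 2 values shown sits). Among the compounds with values here, the single measured step, an at least 15-fold higher number from compound 1 to compound 2 (1.19 log units; beyond the scatter), alters a different group and so does not bear on the present change. Compound 3 `COC(=O)/C=C/c1cccc(N(Cc2ccc(/C=C/C(=O)O)cc2)C(=O)C2CCCCC2)c1` differs from compound 2 by hydrogen in place of methyl on an oxygen next to a carbonyl group. Within the data shown here, no measured step touches this change, so no direction beyond the scatter is expected, and the step that the limit leaves unreadable from compound 2 to compound 3 is the expected outcome. Compound 3 is estimated at 3000 nM, between 800 nM and 15000 nM.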

Compound 3, half-maximal effective concentration: > 1000 nM
Compound 3: only a limit was reported; the forecaster's own chance of this, stated with the estimate: 70%; the middle value lies beyond the limit too.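

Carboxy, like methoxycarbonyl, does not stand in for 2-fluorophenyl in this assay, with an at least 15-fold higher number from compound 1 to compound 3 (1.19 log units; beyond the scatter). Compound 2 and compound 3 both stand at a limit of the assay, and the step between them cannot be read: the limit of > 1000 nM in this assay, at which 2 of the 3 values shown sit. Hydrogen in place of methyl on an oxygen next to a carbonyl group thus brings no value back into the measured range.

On these data alone, how far compound 2 and compound 3 lie beyond that limit stays open. So does whether an amine or an unsubstituted phenyl group on this chain would come closer to compound 1.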